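The source may report more compounds than this note shows. Statements on the series, on what has been measured and on what is new or still open speak of the compounds shown alone.

Among the measured compounds shown here, in an ADME assay on microsomes from liver (Mus musculus) for pharmacokinetics (on this read-out lower numbers stand for slow clearance and higher numbers for fast clearance), compound 2 `C[C@H](NC(=O)[C@@H]1CCCN1C)c1ccc(NC(=O)[C@H]2C[C@@H]2c2cccnc2)cc1` gives 65.4 mL.min-1.g-1, the higher of the two numbers so far, while compound 1 `C[C@H](NC(=O)C1CCOCC1)c1ccc(NC(=O)[C@H]2C[C@@H]2c2cccnc2)cc1` gives 25.1 mL.min-1.g-1. Compound 3 `C[C@H](NC(=O)c1ccccc1)c1ccc(NC(=O)[C@H]2C[C@@H]2c2cccnc2)cc1` alters compound 2 in one place: phenyl in place of 1-methylpyrrolidin-2-yl on a carbonyl carbon. For the measured compounds named here, only one measured step bears on this place on a carbonyl carbon, a 2.6-fold higher number from compound 1 to compound 2 (0.42 log units; beyond the scatter), and it was modest. Phenyl itself has not been measured there, so that step guides only the size, and a small move towards lower numbers is expected. The expected change is a 1.6-fold lower number from compound 2 to compound 3 (0.21 log units; within the scatter). The estimate for compound 3 is 40 mL.min-1.g-1, with a range of 18 mL.min-1.g-1 to 90 mL.min-1.g-1.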

Compound 3, intrinsic clearance in microsomes: 148 mL.min-1.g-1
For compound 3 the middle estimate is 3.7-fold (0.57 log units) below the measured one; the whole stated range lies below it.
By their numbers in this assay, from the lowest: compound 1; then compound 2; then compound 3.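

In this assay, replacing the group on this carbonyl carbon with phenyl gives a 2.3-fold higher number from compound 2 to compound 3 (0.35 log units; beyond the scatter) and a 5.9-fold higher number from compound 1 to compound 3 (0.77 log units; beyond the scatter). Among the compounds shown here, the position can therefore move clearance further than the single earlier step showed, and of these three groups, the aromatic ring of carbon only gives the highest number. No measurement here explains this rise. Still open, from the compounds shown here alone, is where cyclohexyl or pyridin-3-yl on this carbonyl carbon would fall, and so whether the higher number goes with the aromatic ring or with the absence of a ring hetero atom.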